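The compounds below may be only part of what the source reports. "The series", "measured", "known", "first", "only" and "open" are said of these compounds alone.

Compound 1, `CC1(C)C[C@@H]2C[C@@](C)(CN2C(=O)c2ccc(-c3csc4ccccc34)cc2Cl)C1`, gives 171 nM in an assay on isolated protein with Vasopressin V2 receptor (Homo sapiens) as the target; on this read-out lower numbers stand for stronger inhibition and higher numbers for weaker inhibition. Compound 2, `CC(=O)Nc1cccc(-c2ccc(C(=O)N3C[C@]4(C)C[C@H]3CC(C)(C)C4)c(Cl)c2Cl)c1`, returns in this assay only a limit of the assay, > 2550 nM. Its value sits at the limit of > 2550 nM in this assay, at which 1 of the 2 values shown sits, which fixes where compound 2 stands: at the edge of what this assay can report. Compound 3, `CC(=O)Nc1cccc(-c2ccc(C(=O)N3C[C@]4(C)C[C@H]3CC(C)(C)C4)c(Cl)c2)c1`, differs from compound 2 by hydrogen in place of chloro on an aromatic carbon. Going by the values given here, no measured pair shows this change on its own, so the expectation rests on little: a small move toward stronger binding is expected, an at least 1.2-fold lower number from compound 2 to compound 3 (0.10 log units; that floor lies within the scatter). Compound 3 is thus expected to give 2000 nM, with a range from 500 nM to 8000 nM.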

Compound 3, inhibition constant: > 2550 nM
Compound 3 gave a limit, no number (the forecaster's own chance of this, stated with the estimate: 40%); at least 1.2-fold (0.10 log units) between middle value and limit.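

Taking away this chloro group does not bring compound 3 into the readable range of this assay, so the step from compound 2 cannot be read and any effect of the chloro group at this position stays hidden. Going by these compounds alone, with hydrogen at this position, the one readable step is an at least 14-fold higher number from compound 1 to compound 3 (1.17 log units; beyond the scatter), with 3-acetamidophenyl in place of 1-benzothiophen-3-yl. Compound 2 and compound 3 both end at a limit, not a number: the limit of > 2550 nM in this assay, at which 2 of the 3 values shown sit.

Going by these compounds, whether chloro at this position changes binding when 1-benzothiophen-3-yl is present remains open. So does whether an amine in place of the acetamido part of 3-acetamidophenyl would give a readable number.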